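Chain length and sigma-1 binding in a flavone series

This account rests on a few compounds, and the source may have more. Where it says the series, first, only, none or still open, it means among the compounds named here.

Three measured compounds share a phenylchromenone core bearing an ether-linked amine chain. Compound 1 `O=c1cc(-c2ccccc2)oc2cccc(OCCCN3CCC(O)CC3)c12` gives 91 nM in an assay on isolated protein (Cavia porcellus) with Sigma non-opioid intracellular receptor 1 (Homo sapiens) as the target, read by radioligand binding; on this read-out higher numbers stand for weaker inhibition and lower numbers for stronger inhibition. Compound 2 `CN(C)CCCCOc1ccc2oc(-c3ccccc3)cc(=O)c2c1` gives 400 nM in this assay, and compound 3 `CN(C)CCCCCCOc1ccc2oc(-c3ccccc3)cc(=O)c2c1` gives 335 nM. Compound 3 thus sits second highest of the three: its number lies within the scatter of compound 2 and well above that of compound 1, which carries a different chain and amine.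

Compound 4 `CN(C)CCCCCCCCOc1ccc2oc(-c3ccccc3)cc(=O)c2c1` differs from compound 3 by 2-(dimethylamino)ethyl in place of dimethylamino on a saturated chain carbon, six bonds along the chain from an oxygen on an aromatic ring. Going by the values given here, the one measured step that bears on this is a 1.2-fold lower number from compound 2 to compound 3 (0.08 log units; within the scatter), the same kind of extension cut one bond nearer the ether oxygen, and it stayed inside the scatter. Repeating that extension is therefore expected to give at most a small step in this assay, with no direction established, so the expected step is a 1.2-fold lower number from compound 3 to compound 4 (0.08 log units; within the scatter). Compound 4 is estimated at 280 nM, within a range of 90 nM to 900 nM.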

Compound 4, half-maximal inhibitory concentration: 143 nM
Beside the measured number, compound 4's estimate is 2.0-fold (0.29 log units) above it; the range from low to high includes it.
By their numbers in this assay, from the lowest: compounds 1 and 4 (each within the scatter of the next); then compounds 3 and 2 (each within the scatter of the next).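

At this position, six bonds along the chain from an oxygen on an aromatic ring, 2-(dimethylamino)ethyl in place of dimethylamino gives a step that the earlier extension did not: a 2.3-fold lower number from compound 3 to compound 4 (0.37 log units; beyond the scatter) in this assay, beyond the scatter, whereas the same change cut four bonds along gave only a 1.2-fold lower number from compound 2 to compound 3 (0.08 log units; within the scatter), within it. The whole extension, 4-(dimethylamino)butyl in place of dimethylamino at the four-bond position, gives a 2.8-fold lower number from compound 2 to compound 4 (0.45 log units; beyond the scatter), so the change in the number across these three compounds shows up only at the last extension. Nothing measured here explains why the step appears at this position.

From the compounds shown here alone, whether a chain longer than that of compound 4 would lower the number further or raise it again stays open. So does whether diethylamino in place of dimethylamino would give the same steps along these chains.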